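Flipping one ring stereocentre in a bis-guanidine benzofuran

A few compounds are considered here, and "the series" means these few. Any claim that something is new, unique, unknown or untested is made for them only; others in the source may bear on it.

Within the data shown here, compound 3 `N=C(N)NCCCCNC(=O)/C=C/c1ccc2c(c1)[C@@H](C(=O)NCCCCNC(=N)N)[C@H](c1ccc(O)cc1)O2` gives the lowest number of the three so far in an assay on isolated protein (Salivary gland) for displacement of a labelled ligand from Alpha-1A adrenergic receptor (Rattus norvegicus) (a higher number here means a weaker inhibitor, a lower number a stronger inhibitor), with 290000 nM. Its nearest neighbour is compound 1 `COC(=O)[C@@H]1c2cc(/C=C/C(=O)NCCCCNC(=N)N)ccc2O[C@H]1c1ccc(O)cc1`, which in this assay gives 560000 nM; the change a 1.9-fold lower number from compound 1 to compound 3 (0.29 log units; within the scatter) lies within the scatter, so the two cannot be ranked against each other. Compound 2 `N=C(N)NCCCCNC(=O)/C=C/c1ccc(O)cc1` gives 57600000 nM in this assay, a gap beyond the scatter from compound 3.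

Compound 4 `N=C(N)NCCCCNC(=O)/C=C/c1ccc2c(c1)[C@H](C(=O)NCCCCNC(=N)N)[C@H](c1ccc(O)cc1)O2` differs from compound 3 only in configuration: the two compounds have the same atoms and bonds; at least one stereo element is drawn with a configuration in one of them and without one in the other: 1 of 5 stereo elements differ; a stereocentre at a saturated ring carbon is drawn R in compound 3 and S in compound 4. Among the measured compounds shown here, none of the measured steps bears on such a change; the step from compound 1 to compound 3 swaps a group on a carbonyl carbon and says nothing about stereochemistry. For the measured compounds named here, with no precedent, the expected step of a 1.0-fold higher number from compound 3 to compound 4 (0.01 log units; within the scatter) from compound 3 to compound 4 is none beyond the scatter, though the uncertainty is wider than for a well-documented change. Compound 4 is therefore expected to give about 300000 nM in this assay, within a range from 100000 nM to 1000000 nM.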

Compound 4, half-maximal inhibitory concentration: 420000 nM
For compound 4 the middle estimate is 1.4-fold (0.15 log units) below the measured one, and the stated range covers the measured number.
By their numbers in this assay, from the lowest: compounds 3, 4 and 1 (each within the scatter of the next); then compound 2.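

A stereocentre at a saturated ring carbon is all that separates this pair, and in this assay the step is a 1.4-fold higher number from compound 3 to compound 4 (0.16 log units; within the scatter), so the two drawn configurations cannot be told apart here. Among these compounds, this is the first measured pair to isolate configuration, since the earlier step of a 1.9-fold lower number from compound 1 to compound 3 (0.29 log units; within the scatter) swapped a group on a carbonyl carbon instead. The reading still needs one caution about how the structures are drawn: the fact that one of compounds 3 and 4 is drawn with a defined configuration and the other without, at the place where they differ

On these data alone, it remains open whether configuration at this ring carbon would matter equally if a carboxylic acid, or a longer chain ending in a guanidine, stood on that carbonyl carbon. As far as these compounds go, what a change at any of the other stereo elements would do also remains open.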